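The source may report more compounds than this note shows. Statements on the series, on what has been measured and on what is new or still open speak of the compounds shown alone.

Working notes on the series, read in an ADME assay on BJ cells (Homo sapiens) for cytotoxicity, with a stated time of 72 h; a lower number here means that less compound is needed, a higher number that more compound is needed for the effect. Compound 1 `C=C[C@@](C)(/C=C/c1ccc(O)c(/C=C/C(=O)OCc2ccccc2)c1)CCC=C(C)C` gives > 36600 nM, which is a limit of the assay and not a number. Compound 2 `C=C[C@@](C)(/C=C/c1ccc(O)c(/C=C/c2ccc(F)cc2)c1)CCC=C(C)C` gives > 36600 nM, again only a limit, so its standing in this assay is known only as that limit.

The next structure is compound 3 `C=C[C@@](C)(/C=C/c1ccc(O)c(/C=C/C=C/c2ccccc2)c1)CCC=C(C)C`, which carries 2-phenylethenyl in place of 4-fluorophenyl on a double-bonded chain carbon bound to a double-bonded chain carbon. The aromatic ring of carbon only stays, and one double bond outside aromatic rings comes in.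

Going by the values given here, one measured step bears on this change, a step that the two limits leave unreadable from compound 1 to compound 2, and it has no readable size. Among the compounds with values here, the series so far amounts to the limit of > 36600 nM in this assay, at which 2 of the 2 values shown sit. That step exchanged a different group at the same place, and no size can be carried over from it. No step beyond the scatter is therefore expected, and no direction is assigned.

The expected result is a step that the limit leaves unreadable from compound 2 to compound 3. For compound 3 the estimate is 40000 nM, with an expected range of 18000 nM to 70000 nM, and a report as a limit again is the likeliest outcome.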

Compound 3, half-maximal effective concentration: > 36600 nM
Compound 3 ended at the assay's limit (the forecaster's own chance of this, stated with the estimate: 75%); the middle value does not contradict the limit.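

In this assay compound 3 gives > 36600 nM, which is a limit of the assay and not a number. With compound 1 and compound 2 also reported only as limits, no step among these three compounds can be read. The compounds shown leave open where the half-maximal effect of each lies, and whether exchanging the group at this place changes it at all: the limit of > 36600 nM in this assay, at which 3 of the 3 values shown sit.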